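The compounds below may be only part of what the source reports. "The series", "measured", "known", "first", "only" and "open" are said of these compounds alone.

For the measured compounds named here, in a functional assay on the whole organism with Mus musculus as the target (a higher number here means that more compound is needed for the effect, a lower number that less compound is needed), compound 2 `CN1C(=O)CCC1(O)c1cccc(C(F)(F)F)c1` gives 129 mg/kg, the only actual number so far. Compound 1 `O=C1CCC(O)(c2cccc(C(F)(F)F)c2)N1` reaches only a limit, > 200 mg/kg. Going by the values given here, the single measured step is an at least 1.5-fold lower number from compound 1 to compound 2 (0.19 log units; that floor lies within the scatter), and it is known only as a floor because of the limit of > 200 mg/kg in this assay, at which 1 of the 2 values shown sits.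

Compound 3 `CCN1C(=O)CCC1(O)c1cccc(C(F)(F)F)c1` differs from compound 2 by methyl in place of hydrogen on a saturated chain carbon bound to an amide-type nitrogen in a ring, or methyl to ethyl. Among the compounds with values here, the nearest precedent is the methyl placed on that nitrogen in an at least 1.5-fold lower number from compound 1 to compound 2 (0.19 log units; that floor lies within the scatter), which gives no size beyond the scatter. No step beyond the scatter is therefore expected in this assay, and the expected step is a 1.1-fold lower number from compound 2 to compound 3 (0.05 log units; within the scatter). The estimated value for compound 3 is 115 mg/kg, with an expected range of 60 mg/kg to 220 mg/kg.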

Compound 3, dose for half-maximal effect: > 100 mg/kg
Compound 3: no number, only a limit (the forecaster's own chance of this, stated with the estimate: 10%); the middle value is on the limit's open side.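

Compound 3 gives only a limit in this assay, > 100 mg/kg, and no size can be read for its steps from compound 1 or compound 2. Still open, from the compounds shown here alone, is whether ethyl in place of methyl on the amide-type nitrogen in a ring changes the number at all.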